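Side-chain swap on compound 1 in the tail flick test

This account rests on a few compounds, and the source may have more. Where it says the series, first, only, none or still open, it means among the compounds named here.

Measured so far in a functional assay on the whole organism (Tail, strain ICR) with Mus musculus as the target, in the tail flick test, with a stated time of 150 min, at a dose of 25 umol/kg by the oral route; on this read-out lower numbers stand for a weaker effect and higher numbers for a stronger effect at the one dose given:

- compound 1, `NC(=O)CC[C@H](NC(=O)CN(c1ncnc2c1ncn2C1CCCCO1)C1CC1)C(=O)OCc1ccccc1`, gives 10.7%
- compound 2, `O=C(O)[C@@H]1CCCN1C(=O)CN(c1nc(Cl)nc2[nH]cnc12)C1CC1`, gives 7.29%

Compound 1 holds the higher of the two numbers, but compound 2 sits within the scatter of it, so the two values show the same low level of effect and no order between them can be read. Going by the values given here, no step between measured compounds is available, so there is no comparison of any single change to lean on.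

Compound 3, `C[C@@H](O)[C@H](NC(=O)CN(c1ncnc2c1ncn2C1CCCCO1)C1CC1)C(=O)OCc1ccccc1`, is not yet measured. It differs from compound 1 by 1-hydroxyethyl in place of 2-carbamoylethyl on a saturated chain carbon bound to an amide-type nitrogen and a carbonyl carbon.

Among the compounds with values here, with both measured values lying at the low end and no prior step of this kind, the step of a number 0.7 percentage points lower from compound 1 to compound 3 (within the scatter) is expected to be none beyond the scatter. Compound 3 is therefore estimated at 10%, with a range from 0% to 25%.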

Compound 3, a percentage reported as activity, at one dose (the size of the read-out at that dose, not a potency): 6.53%
For compound 3 the middle estimate is 3.5 percentage points above the measured one; measured number inside the range.
By their numbers in this assay, from the lowest: compounds 3, 2 and 1 (each within the scatter of the next).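

In this assay, 1-hydroxyethyl in place of 2-carbamoylethyl on a saturated chain carbon bound to an amide-type nitrogen and a carbonyl carbon gives a number 4.2 percentage points lower from compound 1 to compound 3 (within the scatter). Going by these compounds alone, this is the one direct reading at this position, and it shows that the side-chain amide can be exchanged for a hydroxyl-bearing group with compound 1 and compound 3 remaining at the same low level of effect. No measured property of these compounds bears on this result.

From the compounds shown here alone, whether an amine, a carboxylic acid or a longer chain at this carbon would bring the read-out beyond the scatter from compound 1 stays open. Going by these compounds, the role of the defined stereocentre in 1-hydroxyethyl also stays open, since a single arrangement of it appears here.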